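Hydroxy for methoxy on the chlorophenyl of compound 3

The compounds below may be only part of what the source reports. "The series", "measured", "known", "first", "only" and "open" are said of these compounds alone.

Measured in a functional assay on HOP-62 cells (Homo sapiens) for inhibition, read by sulforhodamine B assay, with a stated time of 48 h; a higher number here means a weaker inhibitor of growth, a lower number a stronger inhibitor of growth:
compound 1 `O=C(Nc1cccc(-n2cc(-c3ccncc3)c(-c3ccc(Cl)c(O)c3)n2)c1)Nc1cccc(C(F)(F)F)c1` 6860 nM
compound 2 `O=C(Nc1cccc(-n2cc(-c3ccncc3)c(-c3ccc(Cl)c(O)c3)n2)c1)Nc1ccc(Cl)c(Cl)c1` 2080 nM
compound 3 `COc1cc(-c2nn(-c3cccc(NC(=O)Nc4ccc(Cl)c(C(F)(F)F)c4)c3)cc2-c2ccncc2)ccc1Cl` 1310 nM

Compound 3 gives the lowest of the three numbers in this assay. Its nearest neighbour is compound 2, whose number is higher but within the scatter; compound 1 stands further off, beyond the scatter. Among the compounds with values here, the one step between two measured compounds that differ in a single place is a 3.3-fold lower number from compound 1 to compound 2 (0.52 log units; beyond the scatter), which concerns the aryl on the urea nitrogen, not the part changed here.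

Compound 4 `O=C(Nc1cccc(-n2cc(-c3ccncc3)c(-c3ccc(Cl)c(O)c3)n2)c1)Nc1ccc(Cl)c(C(F)(F)F)c1` differs from compound 3 by hydrogen in place of methyl on an oxygen on an aromatic ring. Within the data shown here, no measured pair in this set shows this change on its own: compounds 1 and 2 carry the hydroxy but also a different urea aryl from compound 3. The size of the step in this assay therefore cannot be read from any measured pair; with the urea aryl held constant, no movement beyond the scatter is expected either way, so a 1.1-fold higher number from compound 3 to compound 4 (0.06 log units; within the scatter) is the expected step. Compound 4 is estimated at 1500 nM, in the range 500 nM to 4500 nM.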

Compound 4, concentration for 50% growth inhibition: 1220 nM
Compound 4: middle estimate off by 1.2-fold (0.09 log units), on the high side, within the range that was stated.
By their numbers in this assay, from the lowest: compounds 4, 3 and 2 (each within the scatter of the next); then compound 1.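

In this assay, the methoxy to hydroxy change on the chlorophenyl can now be read on its own, with the urea aryl held constant: a 1.1-fold lower number from compound 3 to compound 4 (0.03 log units; within the scatter), so this pair does not tell the two groups apart. With the hydroxy held constant, a 1.7-fold lower number from compound 2 to compound 4 (0.23 log units; within the scatter), so trifluoromethyl and chloro on that aromatic carbon of the urea aryl are not told apart either. Within the data shown here, the one step here beyond the scatter belongs to chloro in place of hydrogen on the urea aryl, a 5.6-fold lower number from compound 1 to compound 4 (0.75 log units; beyond the scatter), not to the oxygen substituent.

No available evidence accounts for any of these steps. Still open, going by these compounds, is how an amine in place of the hydroxy, or an ethyl on that oxygen, would read, and whether methoxy and hydroxy stay level with other urea aryls.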